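Cytotoxicity notes: nitro for bromo at compound 2

The source may hold more compounds than are shown below. What is called first, only, known or untested is meant among the compounds shown, and "the series" means these compounds.

Measured so far in an ADME assay on NIH3T3 cells (Mus musculus) for cytotoxicity, read by MTT assay, with a stated time of 24 h; on this read-out higher numbers stand for weaker inhibition and lower numbers for stronger inhibition:
compound 1 `O=C(CSc1nnnn1-c1ccccc1)N/N=c1/scc(-c2ccc(Br)cc2)n1-c1ccccc1` gives 433 ug/mL
compound 2 `Cn1nnnc1SCC(=O)N/N=c1/scc(-c2ccc(Br)cc2)n1-c1ccccc1` gives 19.3 ug/mL
compound 3 `O=C(CSc1ncccn1)N/N=c1/scc(-c2ccc(Br)cc2)n1-c1ccccc1` gives 273 ug/mL

Compound 2 carries the lowest number of the three; its nearest neighbour is compound 3, and the gap reads a 14-fold higher number from compound 2 to compound 3 (1.15 log units; beyond the scatter). The step of a 22-fold lower number from compound 1 to compound 2 (1.35 log units; beyond the scatter) is of similar size in the other direction, while a 1.6-fold lower number from compound 1 to compound 3 (0.20 log units; within the scatter) stays inside the scatter. All three steps vary the group on the sulfur; none touches the aryl ring.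

Compound 4 `Cn1nnnc1SCC(=O)N/N=c1/scc(-c2ccc([N+](=O)[O-])cc2)n1-c1ccccc1` is not yet measured. Relative to compound 2 the change is nitro in place of bromo on an aromatic carbon. Within the data shown here, no measured pair in this set bears on this change; the sulfur-side steps say nothing about the aryl ring, so the only anchor is the value of compound 2 itself. With no evidence either way, for compound 4 in this assay a step within the scatter is expected, a 1.1-fold higher number from compound 2 to compound 4 (0.06 log units; within the scatter), and the estimate for compound 4 is 22 ug/mL with a range from 7 ug/mL to 70 ug/mL.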

Compound 4, half-maximal inhibitory concentration: 167 ug/mL
Beside the measured number, compound 4's estimate is 7.6-fold (0.88 log units) below it; the whole stated range lies below it.
By their numbers in this assay, from the lowest: compound 2; then compounds 4, 3 and 1 (each within the scatter of the next, the first and the last beyond it).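

In this assay, among these compounds, going from 4-bromophenyl to 4-nitrophenyl gives an 8.7-fold higher number from compound 2 to compound 4 (0.94 log units; beyond the scatter), the only step in this set at the aryl ring. The read-out therefore responds to this position, para to a large group, as well as to the group on the sulfur, and here the replacement of bromo by nitro moves it towards weaker inhibition with 1-methyl-1H-tetrazol-5-yl held fixed on the sulfur. Nothing available accounts for this shift.

From the compounds shown here alone, it remains open whether another group at this position, such as an amine, a carboxylic acid or a methoxy group, would give a number nearer that of compound 2 or further from it. One pair also cannot show whether the same change gives a step of similar size with 1-phenyl-1H-tetrazol-5-yl or pyrimidin-2-yl on the sulfur.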